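This account rests on a few compounds, and the source may have more. Where it says the series, first, only, none or still open, it means among the compounds named here.

Measured compounds:
- compound 1 `C/C=C/C(=O)Nc1cccc(Oc2nc(Nc3ccn(C)n3)nc3c2CSCC3)c1`: in a functional assay on A549 cells (Homo sapiens) for antiproliferative activity, read by MTT assay, with a stated time of 72 h (a lower number here means a stronger inhibitor, a higher number a weaker inhibitor), compound 1 gives > 50000 nM, which is a limit of the assay (the limit of > 50000 nM in this assay, at which 1 of the 3 values shown sits).
- compound 2 `CC/C=C/C(=O)Nc1cccc(Oc2nc(Nc3ccn(C)n3)nc3c2CSCC3)c1`: in this assay compound 2 gives 36800 nM.
- compound 3 `CC/C=C/C(=O)Nc1cccc(Oc2nc(Nc3cccc(C#N)c3)nc3c2CSCC3)c1`: in this assay compound 3 gives 10100 nM.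

The change methyl in place of hydrogen on a saturated chain carbon bound to a double-bonded chain carbon gives an at least 1.3-fold lower number from compound 1 to compound 2 (0.13 log units; that floor lies within the scatter). The change from the 1-methyl-1H-pyrazol-3-yl to the 3-cyanophenyl gives a 3.6-fold lower number from compound 2 to compound 3 (0.56 log units; beyond the scatter). The difference between the core of compound 1 and the core of compound 3 is not broken down here.

Compound 4 `CCC/C=C/C(=O)Nc1cccc(Oc2nc(Nc3cccc(C#N)c3)nc3c2CSCC3)c1` carries the change (methyl in place of hydrogen on a saturated chain carbon, two bonds along the chain from a double-bonded chain carbon). This is the same kind of change as from compound 1 to compound 2, but the place differs: there the methyl entered on a saturated chain carbon bound to a double-bonded chain carbon, here on a saturated chain carbon two bonds along the chain from a double-bonded chain carbon. The step expected from compound 3 to compound 4 is a 1.3-fold lower number from compound 3 to compound 4 (0.10 log units; within the scatter), resting on an at least 1.3-fold lower number from compound 1 to compound 2 (0.13 log units; that floor lies within the scatter), where the earlier methyl gave a small step within the scatter. Compound 4 is therefore estimated at 8000 nM, between 3000 nM and 25000 nM.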

Compound 4, half-maximal inhibitory concentration: 5790 nM
Compound 4: the middle estimate sits 1.4-fold (0.14 log units) above what was measured; measured number inside the range.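

In this assay, methyl in place of hydrogen on the core of compound 3 gives a 1.7-fold lower number from compound 3 to compound 4 (0.24 log units; within the scatter); this step stays within the scatter, so it shows no real gain. Set beside the earlier step, the change appears small on both cores, but whether the two steps differ stays undecided: the same change on two cores in this assay, an at least 1.3-fold lower number (0.13 log units; that floor lies within the scatter) from compound 1 to compound 2 and a 1.7-fold lower number (0.24 log units; within the scatter) from compound 3 to compound 4; the limit leaves it open whether they differ The earlier step rests on a limit for compound 1, so it gives only a floor and no size that can be carried to another core: the limit of > 50000 nM in this assay, at which 1 of the 4 values shown sits.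

The compounds shown leave open whether a longer chain or an amine on the chain would move the number beyond the scatter. They also leave open whether a pent-1-en-1-yl chain behaves alike on the core of compound 1.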